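This account rests on a few compounds, and the source may have more. Where it says the series, first, only, none or still open, it means among the compounds named here.

Values so far in an ADME assay on a cell-free system (plasma, Rattus norvegicus) for metabolic stability, read by LC-MS, with a stated time of 60 min, tested at 100 uM; on this read-out lower numbers stand for a less stable compound and higher numbers for a more stable compound
- compound 1 `Cc1c(OCCCCOCOc2ccc(C(=O)O)cc2)ccc(C(=O)CC2CCCC2)c1O` gives 100%
- compound 2 `COc1cc(C(=O)O)ccc1OCCCCOc1ccc(C(=O)CC(C)C)c(O)c1C` gives 99%
- compound 3 `Cc1c(OCCCCOc2ccc(C(=O)O)cc2)ccc(C(=O)CC(C)C)c1O` gives 95%

Compound 3 lies within the scatter of both compound 1 and compound 2, so the three readings cannot be ordered. Compound 4 `Cc1cc(OCCCCOc2ccc(C(=O)CC(C)C)c(O)c2C)ccc1C(=O)O` differs from compound 3 by a single change, methyl in place of hydrogen on an aromatic carbon, ortho to a carboxy group (methyl in place of hydrogen on an aromatic carbon). Among the measured compounds shown here, one measured step bears on this, a number 4 percentage points lower from compound 2 to compound 3 (within the scatter), where hydrogen replaces methoxy on an aromatic carbon. For the measured compounds named here, no measured step covers methyl itself. The step expected in this assay therefore stays within the scatter, in neither direction, and is estimated as a number 1 percentage points higher from compound 3 to compound 4 (within the scatter). Compound 4 is estimated at 96%, with an expected range from 87% to 100%.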

Compound 4, percent of the compound remaining: 101%
The estimate for compound 4 lay 5 percentage points below the measured number; measured number outside the range, above it.
By their numbers in this assay, from the lowest: compounds 3, 2, 1 and 4 (each within the scatter of the next).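

In this assay, methyl on the aromatic carbon ortho to a carboxy group, the change from 4-carboxyphenyl to 4-carboxy-3-methylphenyl, gives a number 6 percentage points higher from compound 3 to compound 4 (within the scatter) and so leaves the reading within the scatter. Among the compounds shown here, this is the only measured step at this position, and the earlier step, a number 4 percentage points lower from compound 2 to compound 3 (within the scatter), concerned methoxy rather than methyl. Nothing available explains the reading.

The compounds shown leave open whether an ethyl group, a chlorine atom or an amine on this carbon would read differently. They also leave open whether methyl on another carbon of this ring would do so.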